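This account rests on a few compounds, and the source may have more. Where it says the series, first, only, none or still open, it means among the compounds named here.

Compound 1 `Cc1cc(-c2ccco2)c(S(C)(=O)=O)cc1C(=O)N=C(N)N`: 16 nM
Compound 2 `CSc1cc(C)c(C(=O)N=C(N)N)cc1S(C)(=O)=O`: 6 nM
Compound 3 `Cc1cc(OCc2ccccc2)c(S(C)(=O)=O)cc1C(=O)N=C(N)N`: 28 nM

In a functional assay for inhibition of sodium/hydrogen exchanger (Oryctolagus cuniculus) (a lower number here means a stronger inhibitor, a higher number a weaker inhibitor), compound 3 gives the highest of the three numbers: it sits a 1.8-fold higher number from compound 1 to compound 3 (0.24 log units; within the scatter) and a 4.7-fold higher number from compound 2 to compound 3 (0.67 log units; beyond the scatter). Compound 4 `Cc1cc(Oc2ccc(Cl)cc2)c(S(C)(=O)=O)cc1C(=O)N=C(N)N` differs from compound 3 by 4-chlorophenyl in place of benzyl on an oxygen on an aromatic ring. For the measured compounds named here, no measured step alters the group on that oxygen, so only the two steps into compound 3 bear on it, and both stay modest. He therefore expects the step of a 1.1-fold lower number from compound 3 to compound 4 (0.05 log units; within the scatter) to remain small, with no clear direction beyond the scatter. For compound 4 in this assay the estimate is 25 nM, within the range 9 nM to 70 nM.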

Compound 4, half-maximal inhibitory concentration: 13 nM
Compound 4: the middle estimate sits 1.9-fold (0.28 log units) above what was measured; the range from low to high includes it.
By their numbers in this assay, from the lowest: compound 2; then compounds 4, 1 and 3 (each within the scatter of the next, the first and the last beyond it).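

For the compounds shown here, putting 4-chlorophenyl in place of benzyl on an oxygen on an aromatic ring gives a 2.2-fold lower number from compound 3 to compound 4 (0.33 log units; beyond the scatter) in this assay and shows, as no earlier step could, that the group on this oxygen can shift the number beyond the scatter. The same compound keeps methylsulfanyl ahead, with a 2.2-fold higher number from compound 2 to compound 4 (0.34 log units; beyond the scatter) and stays level with furan-2-yl, with a 1.2-fold lower number from compound 1 to compound 4 (0.09 log units; within the scatter) as its reading. No measured evidence accounts for these steps.

This one change cannot separate the chlorine from the change of benzyloxy to a phenoxy. As far as these compounds go, it remains open how unsubstituted phenoxy, an amine or a longer alkoxy chain would read in this place.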